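Amide versus sulfonamide on the piperidine-like nitrogen

This account rests on a few compounds, and the source may have more. Where it says the series, first, only, none or still open, it means among the compounds named here.

Measured compounds:
Compound 1, `COc1ccc(-c2cn3cc(C4=CCN(C(=O)c5ccc(Cl)cc5)CC4)ccc3n2)cc1OC`: 12200 nM
Compound 2, `COc1ccc(-c2cn3cc(C4=CCN(S(=O)(=O)C5CCCC5)CC4)ccc3n2)cc1OC`: 6470 nM
Compound 3, `COc1ccc(-c2cn3cc(C4=CCN(S(=O)(=O)C5CCCCC5)CC4)ccc3n2)cc1OC`: 9990 nM

In a functional assay on HeLa cells (Homo sapiens) for antiproliferative activity, read by MTT assay, with a stated time of 48 h (on this read-out higher numbers stand for weaker inhibition and lower numbers for stronger inhibition), compound 3 gives 9990 nM, the second highest of the three numbers; its nearest neighbour is compound 1 and the furthest is compound 2, and both of those gaps lie within the scatter. Compound 4, `COc1ccc(-c2cn3cc(C4=CCN(C(=O)c5ccccc5)CC4)ccc3n2)cc1OC`, differs from compound 3 in one place: benzoyl in place of cyclohexylsulfonyl on an amine nitrogen in a ring. Among the measured compounds shown here, two measured steps bear on this. The step of a 1.2-fold lower number from compound 1 to compound 3 (0.09 log units; within the scatter) runs in the opposite sense, trading a (4-chlorophenyl)carbonyl for the cyclohexylsulfonyl that now leaves, and the step of a 1.5-fold higher number from compound 2 to compound 3 (0.19 log units; within the scatter) shows the size of the ring on the sulfonyl sulfur mattering little. Neither step leaves the scatter, so no step beyond the scatter is expected in this assay, and the number for compound 4 is expected to sit close to that of compound 1 because of the step of a 1.2-fold lower number from compound 1 to compound 3 (0.09 log units; within the scatter). The estimated step is a 1.1-fold higher number from compound 3 to compound 4 (0.04 log units; within the scatter). Compound 4 is estimated at 11000 nM, with a range from 5000 nM to 25000 nM.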

Compound 4, half-maximal inhibitory concentration: 10200 nM
Compound 4: middle estimate off by 1.1-fold (0.03 log units), on the high side; low and high end bracket the measured number.
By their numbers in this assay, from the lowest: compounds 2, 3, 4 and 1 (each within the scatter of the next).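

In this assay, benzoyl on the amine nitrogen in the ring now stands directly against both sulfonyl groups without a chloro group on the aromatic ring, and neither a 1.0-fold higher number from compound 3 to compound 4 (0.01 log units; within the scatter) nor a 1.6-fold higher number from compound 2 to compound 4 (0.20 log units; within the scatter) leaves the scatter. The new compound also isolates the chloro group itself, and a 1.2-fold lower number from compound 1 to compound 4 (0.08 log units; within the scatter) lies within the scatter too, so all four compounds, amide or sulfonamide, read alike at this position. Nothing given here offers a reason for this sameness.

The compounds shown leave open whether any group on this nitrogen can move the number beyond the scatter, such as a free amine, a carboxylic acid on the benzoyl ring or a longer chain on the sulfonyl sulfur. They also leave open whether a change elsewhere on the shared core would do so.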